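The source may report more compounds than this note shows. Statements on the series, on what has been measured and on what is new or still open speak of the compounds shown alone.

Compounds measured in an ADME assay on a cell-free system (plasma, Homo sapiens) for metabolic stability, with Plasma (Rattus norvegicus) as the target, read by HPLC, at pH 7.4; on this read-out higher numbers stand for a longer-lived compound and lower numbers for a shorter-lived compound:
compound 1 `CC(=O)Oc1ccccc1C(=O)O[C@H]1CO[C@H]2[C@@H]1OC[C@H]2OC(=O)c1ccc(O)cc1`: 0.0198 h
compound 2 `CC(=O)Oc1ccccc1C(=O)O[C@H]1CO[C@H]2[C@@H]1OC[C@H]2OC(=O)c1ccc(C)cc1`: 0.0362 h

Compound 2 gives the highest of the two numbers, with compound 1 nearest at a step within the scatter, a 1.8-fold higher number from compound 1 to compound 2 (0.26 log units; within the scatter). Compound 3 `CC(=O)Oc1ccccc1C(=O)O[C@H]1CO[C@H]2[C@@H]1OC[C@H]2OC(=O)c1ccc(-c2ccccc2)cc1` carries phenyl in place of methyl on an aromatic carbon. Among the compounds with values here, the only measured step at this position, a 1.8-fold higher number from compound 1 to compound 2 (0.26 log units; within the scatter), was small, so a change at the same place gives no ground to expect more than a step within the scatter in this assay. Compound 3 is therefore estimated at 0.04 h, between 0.015 h and 0.11 h, a step of a 1.1-fold higher number from compound 2 to compound 3 (0.04 log units; within the scatter) that is expected to stay within the scatter.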

Compound 3, half-life: > 0.333 h
Compound 3: no number, only a limit; the forecaster's own chance of this, stated with the estimate: 5%; middle value at least 8.3-fold (0.92 log units) away from the limit.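

Methyl and hydroxy on this aromatic carbon had stayed within the scatter in this assay, but a second aromatic ring here changes the picture, with phenyl in place of methyl giving an at least 9.1-fold higher number from compound 2 to compound 3 (0.96 log units; beyond the scatter) and phenyl in place of hydroxy giving an at least 16-fold higher number from compound 1 to compound 3 (1.22 log units; beyond the scatter) in the same read-out. The position is therefore not indifferent to what it carries. Compound 3 reads only as a limit, so neither step has a full size: the limit of > 0.333 h in this assay, at which 1 of the 3 values shown sits.

The compounds shown leave open whether cyclopropyl, a longer chain such as butyl, or an amine at this position would give a comparable step.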